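The source may hold more compounds than are shown below. What is called first, only, known or untested is meant among the compounds shown, and "the series" means these compounds.

Compound 1 `O=c1cc(/C=N\Nc2ccccc2)c2ccc(OCc3ccccc3)cc2o1`: 455000 nM
Compound 2 `O=c1cc(-c2nc3ccccc3[nH]2)c2ccc(OCc3ccccc3)cc2o1`: "not active" (no number reported)

Of the compounds shown here, two have been measured in a functional assay, read by spectrophotometry, with a stated time of 1 h; on this read-out higher numbers stand for weaker inhibition and lower numbers for stronger inhibition. Among the compounds with values here, compound 1 gives 455000 nM, the only number reported, and so it stands as the sole point of reference. Within the data shown here, compound 2 is reported in this assay as "not active" (no number reported), an entry without a number, so no step between the two can be stated beyond what each reading shows. Compound 3 `O=c1cc(/C=N\Nc2ccccc2)c2c(OCc3ccccc3)cc(OCc3ccccc3)cc2o1` has not yet been measured. It differs from compound 1 in one place: benzyloxy in place of hydrogen on an aromatic carbon. Among the measured compounds shown here, no step between measured compounds is available to guide the expectation for this change. Compound 1 is already a very weak inhibitor, and a second benzyloxy group on the shared core is expected to move the read-out by no more than the usual scatter, in either direction. Compound 3 is estimated at 400000 nM, within 100000 nM to 1500000 nM. The expected step from compound 1 to compound 3 is a 1.1-fold lower number from compound 1 to compound 3 (0.06 log units; within the scatter).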

Compound 3, half-maximal inhibitory concentration: 401000 nM
Compound 3: the middle estimate sits 1.0-fold (0.00 log units) below what was measured; the range from low to high includes it.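

In this assay, benzyloxy on an aromatic carbon of the shared core, ortho to a fused ring and meta to a benzyloxy group, gives a 1.1-fold lower number from compound 1 to compound 3 (0.05 log units; within the scatter). Within the data shown here, this is the first step that can be read, and it shows that this position can carry benzyloxy, with its six-membered aromatic ring of carbon only, while the read-out stays within the scatter of that of compound 1. Nothing measured here explains this result.

The compounds shown leave open whether this position is equally silent for other groups, such as an amine, a carboxylic acid or a longer chain. Among these compounds, with only this one step, it also remains open whether any substituent here can move the read-out beyond the scatter.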